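The compounds below may be only part of what the source reports. "The series", "measured", "known", "first", "only" and "open" are said of these compounds alone.

Measured compounds in a functional assay on NCI-H1975 cells (Homo sapiens) for inhibition, read by sulforhodamine B assay, tested at 10 uM; a lower number here means less inhibition, a higher number more inhibition at the concentration tested (going by the name of the read-out):
- compound 1 `CC(=O)N1N=C(c2ccc(-n3cncn3)cc2)CC1c1ccc(N(C)C)cc1` gives -0.3%
- compound 2 `Cc1ccc(S(=O)(=O)N2N=C(c3ccc(-n4cncn4)cc3)CC2c2ccc(N(C)C)cc2)cc1` gives 20%
- compound 3 `C=C(C)C(=O)N1N=C(c2ccc(-n3ccnc3)cc2)CC1c1ccc(N(C)C)cc1` gives -3.7%

Compound 3 sits at the low end of the three numbers. Its value and that of compound 1 lie within the scatter of one another, so no order between them is claimed; compound 2 stands beyond the scatter, higher than compound 3. Among the measured compounds shown here, the only single-change step measured so far is a number 20.3 percentage points higher from compound 1 to compound 2 (beyond the scatter), a (4-methylphenyl)sulfonyl in place of acetyl on the ring amine nitrogen.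

Compound 4 `CN(C)c1ccc(C2CC(c3ccc(-n4ccnc4)cc3)=NN2S(=O)(=O)c2ccc([N+](=O)[O-])cc2)cc1` is not yet measured. Against compound 3 the change is (4-nitrophenyl)sulfonyl in place of (1-methylethenyl)carbonyl on an amine nitrogen in a ring. This is the same kind of exchange as the measured step, an acyl group on the ring nitrogen replaced by an arylsulfonyl group, though here on the imidazole-bearing core and with a nitro rather than a methyl substituent on the entering ring. For the measured compounds named here, only the one step bears on it; nothing shows what the nitro group alone does. A rise of roughly the size seen from compound 1 to compound 2 is therefore expected, beyond the scatter, in this assay.

For compound 4 the expected step is a number 19.7 percentage points higher from compound 3 to compound 4 (beyond the scatter). Compound 4 is estimated at 16%, with a range from 0% to 35%.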

Compound 4, a percentage reported as inhibition, at one concentration (the size of the read-out at that concentration, not a potency): 53%
Compound 4: the middle estimate sits 37 percentage points below what was measured, and the stated range ends below it.
By their numbers in this assay, from the lowest: compounds 3 and 1 (each within the scatter of the next); then compound 2; then compound 4.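

In this assay, among the compounds shown here, the ring amine nitrogen proves able to carry a much larger change than the earlier compounds showed, with a number 56.7 percentage points higher from compound 3 to compound 4 (beyond the scatter), the largest step so far. Read alongside a number 20.3 percentage points higher from compound 1 to compound 2 (beyond the scatter), both steps shown that replace a carbonyl-linked group with an arylsulfonyl group on this nitrogen go upward, on two different cores, and no compound shown goes against this. No measurement shown accounts for the size of the new step.

Compound 4 differs from compound 2 in more than one place, so the contribution of the 4-nitro substituent on the entering ring cannot be separated from that of the core. Still open, as far as these compounds go, is how an unsubstituted phenylsulfonyl, a (4-aminophenyl)sulfonyl or a (4-methoxyphenyl)sulfonyl group would read on the core of compound 4, and whether a (4-nitrophenyl)carbonyl group on the same nitrogen would keep any of the rise without the sulfonyl link.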